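A few compounds are considered here, and "the series" means these few. Any claim that something is new, unique, unknown or untested is made for them only; others in the source may bear on it.

Measured so far in a functional assay on L5178Y cells (Mus musculus) for cytotoxicity, read by MTT assay; on this read-out higher numbers stand for weaker inhibition and lower numbers for stronger inhibition:
- compound 1 `CC(C)(C)c1ccc(OCCCCN2CCN(c3ncccn3)CC2)cc1`: 20.8 nM
- compound 2 `CC(C)(C)c1ccc(OCCCCN2CCN(c3ccccn3)CC2)cc1`: 15.1 nM

Compound 2 is one of only two measured points in this assay, and the two cannot be told apart: compound 1 gives 20.8 nM and compound 2 gives 15.1 nM.

The next compound is compound 3 `CC(C)(C)c1ccc(OCCCCN2CCN(c3cccnc3)CC2)cc1`, which keeps the shared core and changes one group: pyridin-3-yl in place of pyridin-2-yl on an amine nitrogen in a ring. In words, pyridin-3-yl stands in place of pyridin-2-yl on an amine nitrogen in a ring.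

Going by the values given here, only one measured step bears on this change. It is a 1.4-fold lower number from compound 1 to compound 2 (0.14 log units; within the scatter), a swap of the aromatic ring at the same place, and it stays within the scatter. Among the compounds with values here, no measured compound carries pyridin-3-yl, so this single step is weak guidance. With that caution, no step beyond the scatter is expected in this assay, and no direction can be favoured.

The estimated step is a 1.2-fold higher number from compound 2 to compound 3 (0.08 log units; within the scatter). For compound 3 the expected value is 18 nM, with an estimated range of 7 nM to 45 nM.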

Compound 3, half-maximal inhibitory concentration: 11.7 nM
Beside the measured number, compound 3's estimate is 1.5-fold (0.19 log units) above it, within the range that was stated.
By their numbers in this assay, from the lowest: compounds 3, 2 and 1 (each within the scatter of the next).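

In this assay, pyridin-3-yl in place of pyridin-2-yl on an amine nitrogen in a ring gives a 1.3-fold lower number from compound 2 to compound 3 (0.11 log units; within the scatter), and pyridin-3-yl in place of pyrimidin-2-yl at the same place gives a 1.8-fold lower number from compound 1 to compound 3 (0.25 log units; within the scatter). The first of these is a new kind of change for the series: the two groups have the same atoms and the same counts of donors and acceptors and differ only in how those atoms are joined, and this rearrangement of the ring stays within the scatter, as does the swap from pyrimidin-2-yl. Across the three compounds, this position therefore shows no separation among the aromatic rings tried, and no measurement available here speaks to why the numbers lie so close.

As far as these compounds go, whether a phenyl group, with no nitrogen in the ring, or an open-chain amine at this place would step beyond the scatter in this assay remains open. Also open, from the compounds shown here alone, is whether this insensitivity holds with a longer chain in place of the one in the shared core, since all three compounds carry the same chain.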